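The source may report more compounds than this note shows. Statements on the series, on what has been measured and on what is new or still open speak of the compounds shown alone.

Working notes on the series. Within the data shown here, in a functional assay on cells (Melanoma cell, Homo sapiens) for cytotoxicity, read by sulforhodamine B assay, with a stated time of 48 h (a lower number here means a stronger inhibitor of growth, a higher number a weaker inhibitor of growth), compound 1 `O=C1N=C(N2N=C(c3ccccc3)CC2c2ccccc2O)S/C1=C1/C(=O)Nc2ccccc21` gives 4400 nM, the highest of the two numbers measured so far. Among the measured compounds shown here, its only measured neighbour, compound 2 `O=C1N=C(N2N=C(c3ccccc3)CC2c2ccccc2O)S/C1=C1/C(=O)Nc2ccc(Br)cc21`, gives 660 nM in this assay; the change of bromo in place of hydrogen on an aromatic carbon gave a 6.7-fold lower number from compound 1 to compound 2 (0.82 log units; beyond the scatter). Compound 3 `CN(C)c1ccc(C2CC(c3ccccc3)=NN2C2=NC(=O)/C(=C3\C(=O)Nc4ccccc43)S2)cc1` has not been measured. It differs from compound 1 by 4-(dimethylamino)phenyl in place of 2-hydroxyphenyl on a saturated ring carbon. For the measured compounds named here, no measured step touches the group on the saturated ring carbon; the one step measured, from compound 1 to compound 2, sits elsewhere on the core and so gives no direct guide. With nothing to anchor the direction, no step beyond the scatter is expected in this assay, which is what a 1.1-fold lower number from compound 1 to compound 3 (0.04 log units; within the scatter) is taken to mean. Compound 3 is therefore estimated at 4000 nM in this assay, with a range from 1300 nM to 12000 nM reflecting the absence of a comparable measured step.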

Compound 3, concentration for total growth inhibition: 29400 nM
Estimate against measurement, compound 3: 7.4-fold (0.87 log units) below; the whole stated range lies below it.
By their numbers in this assay, from the lowest: compound 2; then compound 1; then compound 3.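

In this assay, among these compounds, the group on the saturated ring carbon proves to matter, a point the earlier compounds left untouched: 4-(dimethylamino)phenyl in place of 2-hydroxyphenyl gives a 6.7-fold higher number from compound 1 to compound 3 (0.82 log units; beyond the scatter) and so moves the number beyond the scatter. This single change removes a hydrogen-bond donor, adds heavy atoms and brings in nitrogen in place of oxygen, and one step cannot separate these differences. No evidence is available to explain this step.

On these data alone, whether the weaker growth inhibition follows from losing the hydroxy group or from gaining the dimethylamino group remains open, and a plain phenyl or a 2-methoxyphenyl on the same carbon would help to separate the two. Also open, as far as these compounds go, is whether the bromo change would give a similar step with 4-(dimethylamino)phenyl on the saturated ring carbon.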